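Series notes: hydroxy to (3-nitrobenzyl)oxy and cytotoxicity

The compounds below may be only part of what the source reports. "The series", "measured", "known", "first", "only" and "open" are said of these compounds alone.

Of the compounds shown here, three have been measured in an ADME assay on cells (Mus musculus, strain BALB/c) for cytotoxicity, read by MTT assay, with a stated time of 24 h; on this read-out lower numbers stand for higher toxicity in this test and higher numbers for lower toxicity in this test. Compound 1 `COc1cc(-c2nnc(SCc3cccc(Br)c3)o2)ccc1O` gives 382000 nM, compound 2 `COc1cc(-c2nnc(SCc3cccc([N+](=O)[O-])c3)o2)ccc1O` gives 392000 nM, and compound 3 `COc1cc(-c2nnc(SCc3ccccc3)o2)ccc1O` gives 211000 nM. All three numbers sit within the scatter of one another: the move a 1.0-fold higher number from compound 1 to compound 2 (0.01 log units; within the scatter), the move a 1.8-fold lower number from compound 1 to compound 3 (0.26 log units; within the scatter) and the move a 1.9-fold lower number from compound 2 to compound 3 (0.27 log units; within the scatter) are each within the usual spread. Compound 2 therefore holds a number that is indistinguishable from those of compound 1 and compound 3, with no ordering to be read from it.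

Compound 4 `COc1cc(-c2nnc(SCc3cccc([N+](=O)[O-])c3)o2)ccc1OCc1cccc([N+](=O)[O-])c1` is yet to be measured. Its change from compound 2 is 3-nitrobenzyl in place of hydrogen on an oxygen on an aromatic ring. For the measured compounds named here, none of the measured steps touches this oxygen; all of them exchange the substituent on the benzyl ring and none moved the number beyond the scatter. Going by the values given here, there is thus no direct precedent for the new group, and the only guidance is that the series so far has been flat.

On that basis compound 4 is expected to stay near compound 2, with an estimated 1.3-fold lower number from compound 2 to compound 4 (0.12 log units; within the scatter), and the estimate for compound 4 is 300000 nM with a range from 100000 nM to 700000 nM.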

Compound 4, half-maximal cytotoxic concentration: 168000 nM
Compound 4: the middle estimate sits 1.8-fold (0.25 log units) above what was measured; measured number inside the range.
By their numbers in this assay, from the lowest: compounds 4, 3, 1 and 2 (each within the scatter of the next, the first and the last beyond it).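

For the compounds shown here, the oxygen on the aromatic ring is the first place where a change moves the number in this assay beyond the scatter: a 2.3-fold lower number from compound 2 to compound 4 (0.37 log units; beyond the scatter), whereas the three exchanges on the benzyl ring all stayed within it. The step is modest and runs toward higher toxicity in this test, so replacing the hydroxy hydrogen with the much larger 3-nitrobenzyl group shifts this read-out only slightly, and the series is not as flat at this oxygen as it is on the benzyl ring. No measurement at hand bears on the reason for this step.

From the compounds shown here alone, this position rests on a single step with a single group, so it remains open whether the shift is specific to 3-nitrobenzyl or would also appear with a small methyl ether, an unsubstituted benzyl or a longer chain ending in a carboxylic acid. Going by these compounds, it is also open whether the same change on this oxygen gives a step of similar size when the other benzyl ring carries bromo or hydrogen, as in compound 1 and compound 3, rather than nitro.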